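This account rests on a few compounds, and the source may have more. Where it says the series, first, only, none or still open, it means among the compounds named here.

Compound 1 `COc1cc(OC)c(-c2coc3cc(OCc4ccccc4F)ccc3c2=O)cc1OC` stands in a functional assay on U-251 cells (Homo sapiens) for antiproliferative activity, read by MTT assay, with a stated time of 24 h (a higher number here means a weaker inhibitor, a lower number a stronger inhibitor), at 2890 nM, the lowest of the two numbers shown. Compound 3 `COc1cc(OC)c(-c2coc3cc(OCc4cccc(F)c4)ccc3c2=O)cc1OC` gives 3510 nM, and the step of a 1.2-fold higher number from compound 1 to compound 3 (0.08 log units; within the scatter) lies within the scatter. Compound 2 `COc1cc(OC)c(-c2coc3cc(OCc4ccccc4C(F)(F)F)ccc3c2=O)cc1OC` reaches only the limit > 10000 nM. Among the measured compounds shown here, the step of an at least 3.4-fold higher number from compound 1 to compound 2 (0.53 log units; beyond the scatter) is the single change made at the same aromatic carbon, with the limit of > 10000 nM in this assay, at which 1 of the 3 values shown sits, marking where compound 2 sits. Compound 4 `COc1cc(OC)c(-c2coc3cc(OCc4ccccc4Br)ccc3c2=O)cc1OC` differs from compound 1 by bromo in place of fluoro on an aromatic carbon. For the measured compounds named here, only that earlier step bears on it; a larger group entering at the same place weakened the number by at least a modest amount, so a smaller weakening is expected for compound 4, as a 1.7-fold higher number from compound 1 to compound 4 (0.24 log units; within the scatter). Compound 4 is therefore estimated at 5000 nM, between 2500 nM and 10000 nM.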

Compound 4, half-maximal inhibitory concentration: > 10000 nM
Compound 4 was reported as a limit (the forecaster's own chance of this, stated with the estimate: 25%); middle value at least 2.0-fold (0.30 log units) from the limit.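

In this assay, the change from fluoro to bromo gives an at least 3.4-fold higher number from compound 1 to compound 4 (0.53 log units; beyond the scatter), and the change from 3-fluorophenyl to 2-bromophenyl gives an at least 2.8-fold higher number from compound 3 to compound 4 (0.45 log units; beyond the scatter). Trifluoromethyl is thus not the only group here to reach a limit, for a change of one heavy atom for one heavy atom does so too, and compound 4, like compound 2, stands at a limit and not at a number: the limit of > 10000 nM in this assay, at which 2 of the 4 values shown sit. The step between these two cannot be read, so bromo and trifluoromethyl cannot be ranked. From the compounds shown here alone, what chloro, methyl or an amine at this aromatic carbon would give remains open.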